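The source may hold more compounds than are shown below. What is called first, only, known or untested is meant among the compounds shown, and "the series" means these compounds.

In a toxicity assay on A549 cells (Homo sapiens) for cytotoxicity, read by luminescence and CellTiter-Glo, with a stated time of 48 h (on this read-out lower numbers stand for higher toxicity in this test and higher numbers for lower toxicity in this test), the measured set is:
compound 1 `CCCCOc1ccc(-c2nc3ncccn3c2NC2CCCC2)cc1`, which gives 40000 nM.
compound 2 `CCCCOc1ccc(-c2nc3ncccn3c2Nc2ccc(F)cc2)cc1`, which gives > 100000 nM, a limit of the assay rather than a number.

For the measured compounds named here, compound 1 thus carries the only number in this assay; the remaining value is a limit. Compound 3 `CCCCOc1ccc(-c2nc3ncccn3c2NCc2ccco2)cc1` differs from compound 1 by (furan-2-yl)methyl in place of cyclopentyl on a nitrogen on an aromatic ring. Going by the values given here, the single measured step, an at least 2.5-fold higher number from compound 1 to compound 2 (0.39 log units; beyond the scatter), swapped the same cyclopentyl for 4-fluorophenyl and moved toward lower toxicity, ending at the limit of > 100000 nM in this assay, at which 1 of the 2 values shown sits. The entering group here is smaller and non-benzenoid, so the step is expected to be modest: a 1.3-fold higher number from compound 1 to compound 3 (0.10 log units; within the scatter). Compound 3 is estimated at 50000 nM, within 20000 nM to 150000 nM.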

Compound 3, half-maximal cytotoxic concentration: 78000 nM
Compound 3: the middle estimate sits 1.6-fold (0.19 log units) below what was measured; the range from low to high includes it.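

In this assay, ((furan-2-yl)methyl) on this nitrogen reads the same as cyclopentyl within the scatter (a 2.0-fold higher number from compound 1 to compound 3 (0.29 log units; within the scatter)), so an aromatic ring here does not by itself give a step beyond the scatter. Against 4-fluorophenyl, the printed floor also stays within the scatter (an at least 1.2-fold lower number from compound 2 to compound 3 (0.10 log units; that floor lies within the scatter)), so these two groups cannot be separated. The value of compound 2 is a limit, not a number: the limit of > 100000 nM in this assay, at which 1 of the 3 values shown sits.

Open, on these data alone, is whether a plain phenyl or a benzyl on this nitrogen would read like 4-fluorophenyl or like (furan-2-yl)methyl. As far as these compounds go, how a basic amine or a carboxylic acid at this place would read also remains open.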